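Swapping the Distal Aryl Group in a Benzanilide Series

This account rests on a few compounds, and the source may have more. Where it says the series, first, only, none or still open, it means among the compounds named here.

Two compounds of this series carry the same amide core. Compound 1 `Cc1cccc(N(C)C(=O)c2ccc(Oc3ccccc3)cc2)c1` in an assay for inhibition of 17-beta-hydroxysteroid dehydrogenase type 1 (Homo sapiens), read by HPLC, with a stated time of 10 min (on this read-out lower numbers stand for stronger inhibition and higher numbers for weaker inhibition), gives "not active" (no number reported). Compound 2 `COc1cccc(N(C)C(=O)c2ccc(-c3ccc(C)c(C)c3)cc2)c1` in this assay gives 13300 nM, which is the only numerical result in hand, with compound 1 reported only as inactive. Compound 3 `COc1ccc(Oc2ccc(C(=O)N(C)c3cccc(OC)c3)cc2)cc1` has not yet been tested. It differs from compound 2 by 4-methoxyphenoxy in place of 3,4-dimethylphenyl on an aromatic carbon. Among the measured compounds shown here, no measured pair isolates this change, so its effect is unknown; given the weak result of compound 2 at 13300 nM and the inactive outcome for compound 1, the step is expected to be small, within the scatter or drifting toward weaker inhibition. The step from compound 2 to compound 3 is therefore estimated at a 1.5-fold higher number from compound 2 to compound 3 (0.18 log units; within the scatter). Compound 3 is expected to give 20000 nM, within a range from 7000 nM to 60000 nM, with a fair chance that only an inactive result is reported.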

Compound 3, half-maximal inhibitory concentration: 9600 nM
Compound 3: middle estimate off by 2.1-fold (0.32 log units), on the high side; the measured number falls inside the stated range.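

Among the compounds shown here, the swap of 3,4-dimethylphenyl for 4-methoxyphenoxy gives the first readable step at this position: in this assay the change is a 1.4-fold lower number from compound 2 to compound 3 (0.14 log units; within the scatter) and so cannot be told apart from repeat variation. This position therefore accepts the exchange without a readable shift in the number, although the entering group carries 2 hydrogen-bond acceptors and the leaving group 0. Nothing available bears on why the two groups read alike.

From the compounds shown here alone, what stays open is whether a group of another kind on this aromatic carbon, such as an amine or a carboxylic acid, would move the number beyond the scatter. Also open, going by these compounds, is whether the same swap would read alike on the core of compound 1, which carries a methyl group where compound 3 has a methoxy group.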